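The source may report more compounds than this note shows. Statements on the series, on what has been measured and on what is new or still open speak of the compounds shown alone.

Series notes, a functional assay on NFF cells (Homo sapiens) for antiproliferative activity; on this read-out lower numbers stand for stronger inhibition and higher numbers for weaker inhibition

- compound 1 `CN(C)c1ccc(C(=O)N[C@@H](CCCCCC(=O)NO)C(=O)NCc2ccccc2)cc1`: 12000 nM
- compound 2 `O=C(CCCCC[C@H](NC(=O)c1ccc(Br)cc1)C(=O)NCc1ccccc1)NO`: 5860 nM
- compound 3 `O=C(CCCCC[C@H](NC(=O)c1cccs1)C(=O)NCc1ccccc1)NO`: 5200 nM

Compound 3 gives the lowest of the three numbers in this assay; its gap to compound 2 is within the scatter, so the two are not separable, and only compound 1 sits clearly apart, as a 2.3-fold lower number from compound 1 to compound 3 (0.36 log units; beyond the scatter) and a 2.0-fold lower number from compound 1 to compound 2 (0.31 log units; beyond the scatter) show.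

Next is compound 4 `O=C(CCCCC[C@H](NC(=O)OCc1ccccc1)C(=O)NCc1ccccc1)NO`, which differs from compound 3 by benzyloxy in place of thiophen-2-yl on a carbonyl carbon.

For the measured compounds named here, the steps that bear on this position are the two exchanges on the same carbonyl carbon: a 1.1-fold lower number from compound 2 to compound 3 (0.05 log units; within the scatter) and a 2.3-fold lower number from compound 1 to compound 3 (0.36 log units; beyond the scatter). Going by the values given here, both were small, and no measured step involves a benzyloxycarbonyl, so the comparison reaches only as far as saying that exchanges of this acyl group have shifted the read-out modestly at most. The expectation for a 1.1-fold higher number from compound 3 to compound 4 (0.02 log units; within the scatter) is therefore a step of no more than the scatter, in either direction. Compound 4 is estimated at 5500 nM, with a range from 1800 nM to 17000 nM.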

Compound 4, half-maximal inhibitory concentration: 1520 nM
The estimate for compound 4 lay 3.6-fold (0.56 log units) above the measured number; measured number below the stated range.
By their numbers in this assay, from the lowest: compound 4; then compounds 3 and 2 (each within the scatter of the next); then compound 1.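

In this assay, the acyl group on the amide-type nitrogen now shows a clear effect, as benzyloxycarbonyl separates compound 4 from all three earlier compounds (a 3.4-fold lower number from compound 3 to compound 4 (0.53 log units; beyond the scatter); a 3.9-fold lower number from compound 2 to compound 4 (0.59 log units; beyond the scatter); a 7.9-fold lower number from compound 1 to compound 4 (0.90 log units; beyond the scatter)). For the compounds shown here, earlier exchanges on this carbonyl carbon had left compounds 2 and 3 inseparable, and only compound 1 stood apart from them, so benzyloxy is the first replacement here to take the read-out beyond the scatter of both. No supporting evidence is available to account for this shift.

Going by these compounds, it remains open whether the oxygen of benzyloxy or its aromatic ring carries the shift. A methoxy or benzylamino group on the same carbonyl carbon would separate those two contributions.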